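A few compounds are considered here, and "the series" means these few. Any claim that something is new, unique, unknown or untested is made for them only; others in the source may bear on it.

Measured so far:
- compound 1, `C=CCn1c(=S)n([C@@H]2O[C@H](CO)[C@H]3OC(C)(C)O[C@H]32)c2nc(N)nc(O)c21`: 9%
- compound 2, `NC(=O)Cn1c(=O)n(C2OC(CO)[C@@H](O)[C@H]2O)c2nc(N)nc(O)c21`: 72%

In a functional assay on the whole organism with Mus musculus as the target (on this read-out lower numbers stand for smaller maximal responses and higher numbers for larger maximal responses), compound 2 stands highest of the two numbers recorded, and the nearest value, that of compound 1, lies well beyond the scatter below it. For the measured compounds named here, no pair of measured compounds that differ in a single place is available, so nothing shows how large a change at the saturated chain carbon bound to an aromatic nitrogen tends to be in this assay.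

Compound 3, `Nc1nc(O)c2c(n1)n(C1OC(CO)[C@@H](O)[C@H]1O)c(=O)n2Cc1ccc(Cl)c(Cl)c1`, is the next to be measured. It differs from compound 2 in one place: 3,4-dichlorophenyl in place of carbamoyl on a saturated chain carbon bound to an aromatic nitrogen

Going by the values given here, with only the two measured values to go on, and no comparable step on record, the direction of the step is uncertain; a downward move beyond the scatter is held as somewhat more likely than none, but the range is kept wide. Compound 3 is expected to reach 45%, with a range from 10% to 85%. The step this estimate implies, a number 27 percentage points lower from compound 2 to compound 3 (beyond the scatter), is expected to exceed the scatter.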

Compound 3, largest response reached (reported as maximal response), in percent of the reference or control that the assay uses: 0%
The estimate for compound 3 lay 45 percentage points above the measured number; measured number outside the range, below it.
By their numbers in this assay, from the lowest: compounds 3 and 1 (each within the scatter of the next); then compound 2.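

In this assay, for the compounds shown here, the first single-place step is large: 3,4-dichlorophenyl in place of carbamoyl on a saturated chain carbon bound to an aromatic nitrogen gives a number 72 percentage points lower from compound 2 to compound 3 (beyond the scatter), and compound 3 ends at 0%. This position is therefore not indifferent to its substituent, and a change here alone is enough to take the maximal response from the level of compound 2 to none. The step swaps a group of 3 heavy atoms with a hydrogen-bond donor and acceptor for one of 8 heavy atoms with an aromatic ring and neither donor nor acceptor, so these differences arrive together, and nothing on record bears on the cause of the step.

Still open, on these data alone, is whether the loss goes with the aromatic ring itself or with its two chlorines, a question that a plain phenyl on the same chain carbon would address. Also open, as far as these compounds go, is how a carboxylic acid, an amine or a longer chain ending in carbamoyl at this position would compare with compound 2.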